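The source may report more compounds than this note shows. Statements on the series, on what has been measured and on what is new or still open speak of the compounds shown alone.

Measured so far:
- compound 1, `COc1ccc(C2CC(Nc3nc4ccc(Cl)cc4s3)=NN2C(C)=O)cc1O`: 132 umol/kg
- compound 2, `COc1ccc(C2CC(Nc3nc4ccc(C)cc4s3)=NN2C(C)=O)cc1O`: 75.6 umol/kg
- compound 3, `COc1ccc(C2CC(Nc3nc4ccc([N+](=O)[O-])cc4s3)=NN2C(C)=O)cc1O`: "not determined" (no result reported)

The read-out is a functional assay on the whole organism (strain albino) with Mus musculus as the target, with a stated time of 0.5 h; a higher number here means that more compound is needed for the effect, a lower number that less compound is needed. Compound 2 shows the lowest of the two numbers available, but its nearest neighbour is compound 1, and the step of a 1.7-fold lower number from compound 1 to compound 2 (0.24 log units; within the scatter) lies within the scatter, so the two cannot be ordered. Compound 3 gives no number in this assay and adds nothing to the comparison.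

The next compound is compound 4, `CC(=O)N1N=C(Nc2nc3ccc(C)cc3s2)CC1c1ccc(Cl)cc1`. It differs from compound 2 in one place: 4-chlorophenyl in place of 3-hydroxy-4-methoxyphenyl on a saturated ring carbon. Among the compounds with values here, no measured step bears on this change; the only step in hand, from compound 1 to compound 2, concerns a substituent on the fused aromatic part of the shared core, not the group on the saturated ring carbon, and it was itself within the scatter. There is therefore no basis in these data for expecting movement in either direction, and the working expectation is no step beyond the scatter, with a wide band to reflect the lack of a reference pair.

Estimated value for compound 4 in this assay: 80 umol/kg, range 35 umol/kg to 200 umol/kg. The expected step is a 1.1-fold higher number from compound 2 to compound 4 (0.02 log units; within the scatter).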

Compound 4, dose for half-maximal effect: 27.5 umol/kg
Compound 4: the middle estimate sits 2.9-fold (0.46 log units) above what was measured; measured number below the stated range.
By their numbers in this assay, from the lowest: compound 4; then compounds 2 and 1 (each within the scatter of the next).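

In this assay, within the data shown here, the group on the saturated ring carbon gives the first step beyond the scatter: 4-chlorophenyl in place of 3-hydroxy-4-methoxyphenyl produces a 2.7-fold lower number from compound 2 to compound 4 (0.44 log units; beyond the scatter), whereas the only earlier step, at a different place on the shared core, was a 1.7-fold lower number from compound 1 to compound 2 (0.24 log units; within the scatter). The place next to the ring nitrogen therefore tolerates loss of the 3-hydroxy-4-methoxyphenyl group, with its 1 hydrogen-bond donor and 2 hydrogen-bond acceptors, and the number moves modestly lower with a group that has 0 of each. No measurement here accounts for this step.

Among these compounds, the single exchange alters the hydroxy, methoxy and chloro substituents together, so it remains open how an unsubstituted phenyl, or a phenyl bearing only the hydroxy or only the methoxy group, would read. Also open, from the compounds shown here alone, are whether a bromo or trifluoromethyl group could stand in for the chloro on this phenyl, and whether the step carries over to the shared core with chloro in place of methyl.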